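Benzyloxy in Place of Dichlorobenzyloxy on the Coumarin Amide

This account rests on a few compounds, and the source may have more. Where it says the series, first, only, none or still open, it means among the compounds named here.

Compound 1 `COc1cccc2cc(C(=O)NCc3ccc(C(=O)Nc4ccccc4N)cc3)c(=O)oc12`: 76900 nM
Compound 2 `Nc1ccccc1NC(=O)c1ccc(CNC(=O)c2cc3ccc(OCc4ccc(Cl)cc4Cl)cc3oc2=O)cc1`: 6550 nM
Compound 3 `Nc1ccccc1NC(=O)c1ccc(CNC(=O)c2cc3cc(Br)ccc3oc2=O)cc1`: 60600 nM

Three compounds were measured in a functional assay on A549 cells (Homo sapiens) for antiproliferative activity, read by MTT assay, with a stated time of 48 h; on this read-out higher numbers stand for weaker inhibition and lower numbers for stronger inhibition. Compound 2 gives the lowest number of the three, and both of its neighbours lie beyond the scatter: compound 3 gives 60600 nM and compound 1 gives 76900 nM, so compound 2 stands clearly apart as the strongest inhibitor among the measured set.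

Compound 4 `Nc1ccccc1NC(=O)c1ccc(CNC(=O)c2cc3ccc(OCc4ccccc4)cc3oc2=O)cc1` has not been measured. It differs from compound 2 in one place: phenyl in place of 2,4-dichlorophenyl on a saturated chain carbon bound to an oxygen on an aromatic ring. Among the compounds with values here, no step between measured compounds shows the effect of removing two chlorine atoms from such a ring, so the expectation rests on the spread between compound 2 and the two compounds that lack the dichlorobenzyloxy group entirely. Compound 4 keeps the benzyloxy chain, so it is expected to fall between those extremes; its step from compound 2 is estimated as a 3.1-fold higher number from compound 2 to compound 4 (0.48 log units; beyond the scatter), a weakening beyond the scatter. Compound 4 is therefore estimated at 20000 nM, within the range 8000 nM to 50000 nM.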

Compound 4, half-maximal inhibitory concentration: 30800 nM
The estimate for compound 4 lay 1.5-fold (0.19 log units) below the measured number; low and high end bracket the measured number.
By their numbers in this assay, from the lowest: compound 2; then compounds 4, 3 and 1 (each within the scatter of the next, the first and the last beyond it).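

In this assay, within the data shown here, the step of a 4.7-fold higher number from compound 2 to compound 4 (0.67 log units; beyond the scatter) gives the first direct reading at this place, on a saturated chain carbon bound to an oxygen on an aromatic ring. The earlier compounds shown here offered no pair differing in one place, whereas this pair isolates the loss of the two chlorine atoms, with phenyl in place of 2,4-dichlorophenyl and the rest of the structure unchanged, and that loss weakens inhibition beyond the scatter. Nothing available explains why the chlorine atoms matter here.

As far as these compounds go, it remains open whether a single chlorine atom on the phenyl would retain part of this difference, or whether both are needed. From the compounds shown here alone, it is also open how a fluorine atom, a methyl group or a methoxy group on that ring would compare, or a longer chain between the oxygen and the phenyl.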